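Replacing the sulfonyl group on the ring nitrogen of compound 2

The source may report more compounds than this note shows. Statements on the series, on what has been measured and on what is new or still open speak of the compounds shown alone.

Of the compounds shown here, two have been measured in a functional assay on MDA-MB-231 cells (Homo sapiens) for antiproliferative activity, read by MTT assay, with a stated time of 48 h; on this read-out lower numbers stand for stronger inhibition and higher numbers for weaker inhibition. Compound 1 `C=CS(=O)(=O)N1CCN(c2nc(OC[C@H]3CCCN3C)nc3sc(-c4ccc(N5CCN(C)CC5)cc4)cc23)[C@@H](C)C1` gives 2880 nM in this assay, and compound 2 `CN1CCN(c2ccc(-c3cc4c(N5CCN(S(=O)(=O)/C=C/c6ccccc6)CC5)ncnc4s3)cc2)CC1` gives 5900 nM, the higher of the two numbers, a gap that lies beyond the usual scatter. Compound 3 `COc1ccccc1NC(=O)N1CCN(c2ncnc3sc(-c4ccc(N5CCN(C)CC5)cc4)cc23)CC1` has not been measured; it differs from compound 2 in one place, ((2-methoxyphenyl)carbamoyl in place of (2-phenylethenyl)sulfonyl on an amine nitrogen in a ring). Within the data shown here, no measured pair isolates this kind of change, so its effect is unknown. Compound 3 is expected to land near compound 2, with the step of a 1.0-fold higher number from compound 2 to compound 3 (0.01 log units; within the scatter) estimated as small in either direction. The estimate for compound 3 is 6000 nM, in the range 1500 nM to 25000 nM.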

Compound 3, half-maximal inhibitory concentration: 23200 nM
Estimate against measurement, compound 3: 3.9-fold (0.59 log units) below, and the stated range covers the measured number.
By their numbers in this assay, from the lowest: compound 1; then compound 2; then compound 3.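

On an amine nitrogen in a ring, the group is not interchangeable: in this assay, (2-methoxyphenyl)carbamoyl in place of (2-phenylethenyl)sulfonyl gives a 3.9-fold higher number from compound 2 to compound 3 (0.59 log units; beyond the scatter), meaning weaker inhibition. Both groups have 11 heavy atoms and one six-membered aromatic ring of carbon only, so these shared counts do not keep the values together. No measurement here accounts for the step. The compounds shown leave open whether the linking carbamoyl or the 2-methoxyphenyl ring carries the step. As far as these compounds go, how a small acetyl group would behave at this nitrogen also remains open.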